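The source may report more compounds than this note shows. Statements on the series, on what has been measured and on what is new or still open speak of the compounds shown alone.

Compound 1 `CCOC(=O)C1=Cc2ccccc2OC1(OCc1cc(-c2ccc(OC)cc2)no1)C(F)(F)F` and compound 2 `CCOC(=O)C1=Cc2ccccc2OC1(OCc1cc(-c2ccc(Cl)cc2)no1)C(F)(F)F` share one core and differ in a single aromatic substituent. In a functional assay on A549 cells (Homo sapiens) for inhibition, read by MTT assay, with a stated time of 24 h (a higher number here means a weaker inhibitor, a lower number a stronger inhibitor), compound 1 gives only a limit, > 150000 nM. In this assay compound 2 gives 19100 nM. Within the data shown here, the step of an at least 7.8-fold lower number from compound 1 to compound 2 (0.89 log units; beyond the scatter) is the only measured change in the set. Among the measured compounds shown here, compound 2 therefore holds the only number among the values shown, the other being (the limit of > 150000 nM in this assay, at which 1 of the 2 values shown sits).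

Compound 3 `CCOC(=O)C1=Cc2ccccc2OC1(OCc1cc(-c2ccc(Br)cc2)no1)C(F)(F)F` differs from compound 2 by bromo in place of chloro on an aromatic carbon. For the measured compounds named here, the one measured step, an at least 7.8-fold lower number from compound 1 to compound 2 (0.89 log units; beyond the scatter), concerns a different exchange at the same aromatic carbon, methoxy for chloro, and no measured pair compares one halogen with another. Going by the values given here, with no step of this kind to draw on, the change from compound 2 to compound 3 is expected to stay within the scatter, a 1.2-fold lower number from compound 2 to compound 3 (0.08 log units; within the scatter). Compound 3 is therefore estimated at 16000 nM, within a range from 6000 nM to 45000 nM.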

Compound 3, half-maximal inhibitory concentration: > 150000 nM
Compound 3: only a limit was reported; the forecaster's own chance of this, stated with the estimate: 5%; middle value at least 9.3-fold (0.97 log units) from the limit.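

In this assay, the exchange of 4-chlorophenyl for 4-bromophenyl gives an at least 7.8-fold higher number from compound 2 to compound 3 (0.89 log units; beyond the scatter), so at this aromatic carbon one halogen does not simply stand in for the other. Of the three substituents, only the chloro of compound 2 yields a number, while compound 1 and compound 3 each give only a limit of the assay: the limit of > 150000 nM in this assay, at which 2 of the 3 values shown sit. The step between compound 1 and compound 3 cannot be read, as both values are limits.

The compounds shown leave open whether the number of compound 2 is unique to chloro or would also appear with fluoro, a nitrile or a trifluoromethyl group on this carbon. They also leave open whether a carboxylic acid in place of the ethyl ester would change the reading of the chloro compound.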